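A few compounds are considered here, and "the series" means these few. Any claim that something is new, unique, unknown or untested is made for them only; others in the source may bear on it.

Compound 1 `COCOc1cc(/C=C/C(=O)OCC(=O)Nc2ccc(OC)cc2)ccc1OCc1ccccc1` in a functional assay on HeLa cells (Homo sapiens) for cytotoxicity, read by MTT assay, with a stated time of 72 h (a higher number here means a weaker inhibitor, a lower number a stronger inhibitor), gives 155000 nM. Compound 2 `COCOc1cc(/C=C/C(=O)OCC(=O)Nc2ccc(Cl)cc2)ccc1OCc1ccccc1` reaches only a limit of this assay, > 200000 nM. The change between them, (chloro in place of methoxy on an aromatic carbon), moves the value by an at least 1.2-fold higher number from compound 1 to compound 2 (0.11 log units; that floor lies within the scatter); as a cause nothing is shown beyond (the limit of > 200000 nM in this assay, at which 2 of the 3 values shown sit), where the value of compound 2 sits.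

Compound 3 `COc1ccc(NC(=O)COC(=O)/C=C/c2cc(OC)c(OCc3ccc(Cl)c(Cl)c3)c(OC)c2)cc1` also sits at a limit in this assay, > 200000 nM. How its core differs from that of compound 1 is not broken down here.

Compound 4 `COc1cc(/C=C/C(=O)OCC(=O)Nc2ccc(Cl)cc2)cc(OC)c1OCc1ccc(Cl)c(Cl)c1` is not yet measured. It differs from compound 3 by chloro in place of methoxy on an aromatic carbon, the same change with the same place as from compound 1 to compound 2. Given that compound 3 already shows only a limit, > 200000 nM, compound 4 is expected to stay at or beyond that limit, a step that the limit leaves unreadable from compound 3 to compound 4. Compound 4 is estimated at 300000 nM, between 150000 nM and 1000000 nM.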

Compound 4, half-maximal inhibitory concentration: > 200000 nM
Compound 4 was reported as a limit; the forecaster's own chance of this, stated with the estimate: 85%; the middle value does not contradict the limit.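

Compound 4 reaches only a limit in this assay, > 200000 nM. Going by these compounds alone, compound 3 also stands at a limit, and no step from compound 3 to compound 4 can be read. The compounds shown leave open what chloro in place of methoxy does on the core of compound 3.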